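The source may hold more compounds than are shown below. What is called first, only, known or untested is meant among the compounds shown, and "the series" means these compounds.

Compound 1 `CNC1=NS(=O)(=O)c2cc(F)ccc2N1`: > 300 uM
Compound 2 `CNC1=NS(=O)(=O)c2cc(Br)ccc2N1`: 31 uM

Both values come from a functional assay (aorta) with Rattus norvegicus as the target; a lower number here means that less compound is needed, a higher number that more compound is needed for the effect. The entry for compound 1, > 300 uM, is a limit of the assay and not a number. For the measured compounds named here, compound 2 therefore holds the only true number so far, 31 uM.

Going by the values given here, the one measured step, an at least 9.6-fold lower number from compound 1 to compound 2 (0.98 log units; beyond the scatter), is bromo in place of fluoro on an aromatic carbon. Compound 3 `CCC(C)NC1=NS(=O)(=O)c2cc(Br)ccc2N1` keeps that bromo and changes a different place: sec-butyl in place of methyl on an amine nitrogen. Among the compounds with values here, this is sec-butyl in place of methyl on an amine nitrogen, and no measured step covers a change there. The step of an at least 9.6-fold lower number from compound 1 to compound 2 (0.98 log units; beyond the scatter) therefore bears on it only loosely, showing that one small swap can move a compound beyond the scatter in this assay. On this thin evidence, a step of similar size towards a lower number is expected, though the direction is a judgment and the opposite remains possible. The expected change is a 7.8-fold lower number from compound 2 to compound 3 (0.89 log units; beyond the scatter). Compound 3 is estimated at 4 uM, with an expected range of 0.8 uM to 20 uM.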

Compound 3, concentration for half-maximal effect: 5.6 uM
Beside the measured number, compound 3's estimate is 1.4-fold (0.15 log units) below it; measured number inside the range.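

In this assay, the amine nitrogen proves to be a second place on the shared core where a single swap matters: sec-butyl in place of methyl gives a 5.5-fold lower number from compound 2 to compound 3 (0.74 log units; beyond the scatter). Until now, only the swap on an aromatic carbon had been seen to move the number, so this result shows that the group on the nitrogen also counts, here with the bromo kept in place and the chain growing from 1 carbon to 4. This step also runs between two true numbers and so has a definite size, whereas the earlier step has a limit of the assay at one end: the limit of > 300 uM in this assay, at which 1 of the 3 values shown sits.

Because this is a single pair, it sets no trend, and the compounds shown leave open whether a straight n-butyl chain, a cyclopentyl ring or a chain ending in an amine on the same nitrogen would bring the number lower still or raise it again. They also leave open whether sec-butyl would give a step of similar size with fluoro or chloro in place of the bromo.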